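This account rests on a few compounds, and the source may have more. Where it says the series, first, only, none or still open, it means among the compounds named here.

Measured in an ADME assay on HepG2 cells (Homo sapiens) for cytotoxicity, read by MTT assay, with a stated time of 72 h; a higher number here means that more compound is tolerated, a lower number that less compound is tolerated:

- compound 1 `CCCCCCCNc1nc2cc(-c3ccc(C)cc3)sc2c(=O)[nH]1` gives 6800 nM
- compound 2 `Cc1ccc(-c2cc3nc(NC(C)c4ccccc4)[nH]c(=O)c3s2)cc1` gives 9200 nM
- compound 3 `CC(C)Nc1nc2cc(-c3ccc(Cl)cc3)sc2c(=O)[nH]1` gives > 15600 nM

Compound 3 stands at the limit of > 15600 nM in this assay, at which 1 of the 3 values shown sits. This is a limit and not a number, so the starting point of the step is open on one side.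

Compound 4 `COc1ccc(-c2cc3nc(NC(C)C)[nH]c(=O)c3s2)cc1` is not yet measured. It carries methoxy in place of chloro on an aromatic carbon, para to a large group: methoxy in place of chloro on an aromatic carbon.

Among the compounds with values here, no measured step makes this swap. The only one at hand is a 1.4-fold higher number from compound 1 to compound 2 (0.13 log units; within the scatter), and it changes a different place, the group on the nitrogen, so it is a loose guide. A step beyond the scatter in this assay is not expected in either direction, because a 1.4-fold higher number from compound 1 to compound 2 (0.13 log units; within the scatter) is all there is to go on. The assay may well report a limit again for compound 4.

The estimated step is a step that the limit leaves unreadable from compound 3 to compound 4.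

For compound 4 the expected value is 16000 nM, with an estimated range from 8000 nM to 32000 nM.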

Compound 4, half-maximal cytotoxic concentration: 27100 nM
Compound 4: middle estimate off by 1.7-fold (0.23 log units), on the low side, within the range that was stated.
By their numbers in this assay, from the lowest: compounds 1 and 2 (each within the scatter of the next); then compound 4.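

The step from compound 3 to compound 4 cannot be read, because compound 3 stands at a limit and not at a number: the limit of > 15600 nM in this assay, at which 1 of the 4 values shown sits.

The compounds shown leave open whether methoxy in place of chloro on an aromatic carbon changes the tolerated concentration at all, and by how much.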